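The compounds below may be only part of what the source reports. "The series", "measured", "known", "first", "only" and "open" are said of these compounds alone.

Measured so far in a functional assay on HCT-116 cells (Homo sapiens) for inhibition, read by MTT assay, with a stated time of 72 h; a higher number here means a weaker inhibitor, a lower number a stronger inhibitor:
- compound 1 `Cc1ccc2c(c1)/C(=N/NC(=S)N1CCN(c3ccccc3)CC1)C(=O)N2`, giving 9480 nM
- compound 2 `O=C1Nc2ccc(Cl)cc2/C1=N/NC(=S)N1CCN(c2ccccc2)CC1`, giving 3490 nM
- compound 3 `O=C1Nc2ccc([N+](=O)[O-])cc2/C1=N/NC(=S)N1CCN(c2ccccc2)CC1`, giving 15100 nM

Compound 2 holds the lowest of the three numbers in this assay. Its nearest neighbour is compound 1, with a step of a 2.7-fold lower number from compound 1 to compound 2 (0.43 log units; beyond the scatter), so chloro in place of methyl on the aromatic carbon of the shared core moves the number down beyond the scatter. Its furthest neighbour is compound 3, with a 4.3-fold higher number from compound 2 to compound 3 (0.64 log units; beyond the scatter), so nitro in that position moves the number up beyond the scatter. Between compound 1 and compound 3 the step is a 1.6-fold higher number from compound 1 to compound 3 (0.20 log units; within the scatter) and stays within the scatter.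

Compound 4 `Cc1ccc(N2CCN(C(=S)N/N=C3\C(=O)Nc4ccc(Cl)cc43)CC2)c(C)c1` keeps the chloro of compound 2 and changes a different part of the molecule: 2,4-dimethylphenyl in place of phenyl on an amine nitrogen in a ring. None of the three measured steps touches the group on that ring nitrogen; all of them vary the aromatic carbon of the core. Going by the values given here, there is therefore no measured step that bears directly on this change, and no direction can be drawn from the data. The expectation is a step from compound 2 of a 1.0-fold higher number from compound 2 to compound 4 (0.00 log units; within the scatter), not beyond the scatter, with a wide range to reflect the absence of a precedent. Compound 4 is estimated at 3500 nM, within 1200 nM to 10000 nM.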

Compound 4, half-maximal inhibitory concentration: 7180 nM
Estimate against measurement, compound 4: 2.1-fold (0.31 log units) below; the range from low to high includes it.
By their numbers in this assay, from the lowest: compound 2; then compounds 4, 1 and 3 (each within the scatter of the next, the first and the last beyond it).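

In this assay, going by these compounds alone, the group on the ring nitrogen also affects the number: 2,4-dimethylphenyl in place of phenyl gives a 2.1-fold higher number from compound 2 to compound 4 (0.31 log units; beyond the scatter), a modest step, whereas the earlier steps varied only the aromatic carbon of the shared core. Within the data shown here, with the chloro held fixed, this larger aryl group moves the number up rather than down, so the one change tested at this position does not improve on the phenyl of compound 2, although a single pair sets no trend for the position. Nothing available on these compounds accounts for the step.

As far as these compounds go, it remains open whether both methyl groups of the 2,4-dimethylphenyl contribute to the step, and whether the same change would move the number in the same direction on the methyl or nitro versions of the core. Also open, from the compounds shown here alone, is how the number would respond to a different group on the ring nitrogen, such as a methoxy-substituted phenyl, a pyridine ring or a benzyl group.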